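From Isopropyl to Bromo: Expecting Little Change

The compounds below may be only part of what the source reports. "The series", "measured", "known", "first", "only" and "open" are said of these compounds alone.

Three amides were run in a functional assay on the whole organism for inhibition, with Rattus norvegicus as the target, at a dose of 3 mg/kg by the oral route; on this read-out higher numbers stand for a stronger effect at the one dose given and lower numbers for a weaker effect. Compound 1 `CCc1ccnc(C(=O)Nc2nn[nH]n2)c1` gives 29%, compound 2 `O=C(Nc1nn[nH]n1)c1cccc(Br)n1` gives 38%, and compound 3 `CC(C)c1ccnc(C(=O)Nc2nn[nH]n2)c1` gives 34%. Compound 3 stands second of the three numbers, with compound 2 nearest and compound 1 furthest, and both of those gaps lie within the scatter. Within the data shown here, the only single-point step among the measured compounds is a number 5 percentage points higher from compound 1 to compound 3 (within the scatter), methyl in place of hydrogen on a saturated chain carbon bound to an aromatic carbon and a saturated chain carbon, and it stays within the scatter.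

Compound 4 `O=C(Nc1nn[nH]n1)c1cc(Br)ccn1` differs from compound 3 by bromo in place of isopropyl on an aromatic carbon. Among the measured compounds shown here, no measured step covers a bromo entering for an isopropyl; compound 2 carries a bromo too, but at another place, so its value and that of compound 3 can only be set side by side, and they lie within the scatter of each other. With nothing beyond the scatter among the measured numbers, compound 4 is expected to show no change at the digits printed from compound 3 to compound 4 (within the scatter), a step not beyond the scatter. The estimate for compound 4 in this assay is therefore 34%, with a range from 17% to 51%.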

Compound 4, a percentage reported as inhibition, in the whole organism at one dose (the size of the read-out at that dose, not a potency): 34%
Estimate against measurement, compound 4: no gap at the digits printed; measured number inside the range.
By their numbers in this assay, from the lowest: compounds 1, 3, 4 and 2 (each within the scatter of the next).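

In this assay the step of no change at the digits printed from compound 3 to compound 4 (within the scatter) comes with bromo in place of isopropyl on the aromatic carbon opposite the ring nitrogen, so going from 3 heavy atoms to 1 heavy atom at this position leaves the number within the scatter. The step of a number 5 percentage points higher from compound 1 to compound 4 (within the scatter) with bromo in place of ethyl stays within the scatter as well, so ethyl, isopropyl and bromo cannot be told apart here at the one dose given. No measurement shown bears on why these groups read alike.

As far as these compounds go, it remains open whether an amine, a carboxylic acid or a longer chain such as butyl on this aromatic carbon would move the number beyond the scatter. From the compounds shown here alone, it also remains open whether ethyl, isopropyl and bromo would still read alike at other doses.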